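Swapping Nitro for Propanoylamino: Expected Change in Cytotoxicity

A few compounds are considered here, and "the series" means these few. Any claim that something is new, unique, unknown or untested is made for them only; others in the source may bear on it.

Compound 3 `O=[N+]([O-])c1ccc(-c2nc3cc(C(F)(F)F)ccc3[nH]2)cc1` gives 6000 nM in an ADME assay on MT4 cells (Homo sapiens) for cytotoxicity, read by MTT assay, with a stated time of 96 h (a higher number here means that more compound is tolerated, a lower number that less compound is tolerated), the lowest of the three numbers measured. Compound 2 `Oc1ccc(-c2nc3cc(C(F)(F)F)ccc3[nH]2)cc1` gives 17000 nM, and compound 1 `CCC(=O)Nc1ccc(-c2nc3cc(C(F)(F)F)ccc3n2C2CCCCC2)cc1`, which already carries the propanoylamino group, gives 17000 nM. Within the data shown here, the only measured step, a 2.8-fold lower number from compound 2 to compound 3 (0.45 log units; beyond the scatter), shows the nitro compound with a clearly lower number than the hydroxy compound. Compound 4 `CCC(=O)Nc1ccc(-c2nc3cc(C(F)(F)F)ccc3[nH]2)cc1` reverses that kind of change: propanoylamino in place of nitro on an aromatic carbon. With compound 2 and compound 1 both standing higher than compound 3, a modest step back upward beyond the scatter is expected here. Compound 4 is therefore expected to give about 15000 nM, within a range of 6000 nM to 38000 nM, an expected step of a 2.5-fold higher number from compound 3 to compound 4 (0.40 log units; beyond the scatter).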

Compound 4, half-maximal cytotoxic concentration: >= 100000 nM
Compound 4: no number, only a limit; the forecaster's own chance of this, stated with the estimate: 10%; middle value at least 6.6-fold (0.82 log units) away from the limit.
By their numbers in this assay, from the lowest: compound 3; then compounds 1 and 2 (each within the scatter of the next). At a limit, above all of these: compound 4.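

In this assay, the result for compound 4 is a limit and not an exact number: the limit of >= 100000 nM in this assay, at which 1 of the 4 values shown sits. Among these compounds, on this aromatic carbon, para to a large group, the choice of substituent matters more than the earlier compounds showed: propanoylamino gives an at least 16-fold higher number from compound 3 to compound 4 (1.22 log units; beyond the scatter) and an at least 5.8-fold higher number from compound 2 to compound 4 (0.76 log units; beyond the scatter). The aromatic nitrogen also matters, as hydrogen in place of cyclohexyl, with propanoylamino kept, gives an at least 5.8-fold higher number from compound 1 to compound 4 (0.76 log units; beyond the scatter).

Going by these compounds, whether a plain amine or a longer acyl chain on that carbon would also reach the limit remains open. So does the effect of a methyl group on the nitrogen.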